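Growth inhibition notes: cyclopentyl to cyclohexyl on oxygen

This account rests on a few compounds, and the source may have more. Where it says the series, first, only, none or still open, it means among the compounds named here.

Values in a functional assay on MCF7 cells (Homo sapiens) for inhibition, read by sulforhodamine B assay, with a stated time of 48 h (on this read-out lower numbers stand for stronger inhibition of growth and higher numbers for weaker inhibition of growth), are as follows:
- compound 1 `c1cc(C2CCCCC2)ccc1NC1=NCCO1` gives 17500 nM
- compound 2 `c1ccc(-c2ccc(NC3=NCCO3)cc2)cc1` gives 10600 nM
- compound 3 `c1cc(OC2CCCC2)ccc1NC1=NCCO1` gives 23100 nM

Two steps show where compound 3 stands: a 1.3-fold higher number from compound 1 to compound 3 (0.12 log units; within the scatter) and a 2.2-fold higher number from compound 2 to compound 3 (0.34 log units; beyond the scatter) on this read-out. It therefore sits level with compound 1 and apart from compound 2.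

Compound 4 `c1cc(OC2CCCCC2)ccc1NC1=NCCO1` is not yet measured. Its difference from compound 3 is cyclohexyl in place of cyclopentyl on an oxygen on an aromatic ring and amounts to cyclohexyl in place of cyclopentyl on an oxygen on an aromatic ring. Among the measured compounds shown here, no measured step makes this exact change. The closest evidence is a 1.3-fold higher number from compound 1 to compound 3 (0.12 log units; within the scatter) together with a 1.7-fold lower number from compound 1 to compound 2 (0.22 log units; within the scatter) and both stay within the scatter. Compound 2 goes against this quiet picture, but its step to compound 3 is only modest. No step beyond the scatter is therefore expected in this assay for this small ring change.

The expected step is a 1.2-fold lower number from compound 3 to compound 4 (0.06 log units; within the scatter) in this direction and size.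

For compound 4 the estimated value is 20000 nM with an expected range from 10000 nM to 38000 nM as the working figure.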

Compound 4, concentration for 50% growth inhibition: 19100 nM
Compound 4: middle estimate off by 1.0-fold (0.02 log units), on the high side; measured number inside the range.
By their numbers in this assay, from the lowest: compounds 2, 1, 4 and 3 (each within the scatter of the next, the first and the last beyond it).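

On an oxygen on an aromatic ring, going from cyclopentyl to cyclohexyl gives a 1.2-fold lower number from compound 3 to compound 4 (0.08 log units; within the scatter) in this assay, so this one-carbon ring enlargement leaves the read-out unchanged within the scatter. Earlier steps replaced whole groups on an aromatic carbon, whereas this step keeps the oxygen and alters only the ring, and the two ring sizes tested on that oxygen cannot be told apart. No measured evidence is available to explain this insensitivity.

The compounds shown carry only carbon rings on this oxygen, so it remains open whether a group such as an amine or a carboxylic acid at the end of a longer chain would give a step beyond the scatter. On these data alone, whether the flat response to ring size extends to smaller rings, such as cyclopropyl, also remains open.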